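The source may hold more compounds than are shown below. What is called first, only, known or untested is meant among the compounds shown, and "the series" means these compounds.

Compound 1, `CCOC(=O)CSc1nncc2cnc(C)n12`, gives 52000 nM in a functional assay for inhibition, with Homo sapiens as the target; a higher number here means a weaker inhibitor, a lower number a stronger inhibitor. Compound 2, `Cc1ncc2cnnc(S)n12`, reaches only the limit of > 48000 nM in this assay. Compound 3, `CCCc1ncc2cnnc(SC)n12`, likewise reaches only the limit of > 48000 nM in this assay.

Compound 3 therefore stands at the limit of > 48000 nM in this assay, at which 2 of the 3 values shown sit, with no number of its own; all three measured compounds are weak inhibitors in this assay. Compound 4, `CSc1nncc2cnc(C)n12`, differs from compound 3 by hydrogen in place of ethyl on a saturated chain carbon bound to an aromatic carbon. Within the data shown here, no measured pair isolates this change, so its size cannot be read from the data. Given that every measured compound sits at or near the same weak level, the step from compound 3 to compound 4 is expected to be none beyond the scatter, as a step that the limit leaves unreadable from compound 3 to compound 4 states. Compound 4 is thus estimated at 55000 nM, between 20000 nM and 160000 nM, most likely reported again only as a limit.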

Compound 4, half-maximal inhibitory concentration: > 48000 nM
Compound 4 gave a limit, no number; the forecaster's own chance of this, stated with the estimate: 70%; the middle value is on the limit's open side.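

Among these compounds, no step to compound 4 from compound 1, compound 2 or compound 3 can be read, as compound 4 too gives only a limit: the limit of > 48000 nM in this assay, at which 3 of the 4 values shown sit. The compounds shown leave open what any of these changes does to inhibition in this assay.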